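Aryl replacement on the thioether ketone arm

This account rests on a few compounds, and the source may have more. Where it says the series, first, only, none or still open, it means among the compounds named here.

Measured so far in a functional assay on A549 cells (Homo sapiens) for inhibition, read by sulforhodamine B assay, with a stated time of 48 h, tested at 10 uM; on this read-out lower numbers stand for less inhibition of growth and higher numbers for more inhibition of growth at the one concentration tested:
compound 1 `CC(=O)c1ccc(Nc2ccnc(SCC(=O)c3ccc(Br)cc3)n2)cc1`: 10%
compound 2 `CC(=O)c1cccc(Nc2ccnc(SCC(=O)c3ccc(-c4ccccc4)cc3)n2)c1`: 14%
compound 3 `CC(=O)c1ccc(Nc2ccnc(SCC(=O)c3ccc(Cl)cc3)n2)cc1`: 20%

Compound 3 stands at the top of the three numbers, but not by a margin that counts. Among the compounds with values here, the only single-point step measured, a number 10 percentage points higher from compound 1 to compound 3 (within the scatter), is within the scatter. Within the data shown here, compound 2 gives a figure close to that of compound 3 as well, so nothing in this assay separates the three so far.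

Compound 4 `CC(=O)c1ccc(Nc2ccnc(SCC(=O)c3ccc(-c4ccccc4)cc3)n2)cc1` is not yet measured. It differs from compound 3 by phenyl in place of chloro on an aromatic carbon. Among the measured compounds shown here, no measured step bears directly on this exchange; the halogen swap from compound 1 to compound 3 was within the scatter, and compound 2, which carries the same phenyl on a core that differs elsewhere, gives a number within the scatter of compound 3. On that basis no step beyond the scatter is expected in this assay, in either direction. The expected step is a number 4 percentage points lower from compound 3 to compound 4 (within the scatter). For compound 4 the estimate is 16%, with a range from 5% to 28%.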

Compound 4, percent growth inhibition at one concentration: 20%
Compound 4: middle estimate off by 4 percentage points, on the low side; measured number inside the range.
By their numbers in this assay, from the lowest: compounds 1, 2, 3 and 4 (each within the scatter of the next).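

Working notes on the phenyl exchange: in this assay, phenyl in place of chloro on an aromatic carbon, para to a large group, gives no change at the digits printed from compound 3 to compound 4 (within the scatter) and so adds one six-membered aromatic ring of carbon only at this position on the shared core without a step beyond the scatter. On the same core, phenyl in place of bromo gives a number 10 percentage points higher from compound 1 to compound 4 (within the scatter) as its reading, so bromo, chloro and phenyl are not separated at this position in this assay. Within the data shown here, with phenyl held in place, 4-acetylphenyl in place of 3-acetylphenyl on the nitrogen gives a number 6 percentage points higher from compound 2 to compound 4 (within the scatter) as the first single-place reading for that change, and it does not separate the two arrangements either. No evidence on the reason for these readings is at hand.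

Open, going by these compounds, is whether an amine or a carboxylic acid at this position on the aromatic ring would give a step beyond the scatter. Also open, on these data alone, is whether a longer chain in place of the acetyl group on the acetylphenyl arm would separate itself from these four compounds in this read-out at its single concentration.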